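A cyclopropyl replaces the substituted pyrazole

A few compounds are considered here, and "the series" means these few. Any claim that something is new, unique, unknown or untested is made for them only; others in the source may bear on it.

In a physicochemical assay for lipophilicity (a higher number here means a more lipophilic compound, a lower number a more polar compound), compound 3 `Cc1cc(C)n(-c2ccc(Cl)c(C(=O)NC(=O)Nc3nc4ccc(S(=O)(=O)CCCN5CCN(C)CC5)cc4s3)c2)n1` stands highest at 2.5, ahead of compound 2 `CN1CCN(CCCS(=O)(=O)c2ccc3nc(NC(=O)NC(=O)c4cc(-n5cccn5)ccc4Cl)sc3c2)CC1` at 2 and compound 1 `CN1CCN(CCCS(=O)(=O)c2ccc3nc(NC(=O)NC(=O)c4cccc(-n5cccn5)c4Cl)sc3c2)CC1` at 1.6. Compound 4 `CN1CCN(CCCS(=O)(=O)c2ccc3nc(NC(=O)NC(=O)c4cc(C5CC5)ccc4Cl)sc3c2)CC1` is the next structure to assess, and its change from compound 3 is: cyclopropyl in place of 3,5-dimethyl-1H-pyrazol-1-yl on an aromatic carbon. The closest measured step is a number 0.50 log units higher from compound 2 to compound 3 (beyond the scatter), with 3,5-dimethyl-1H-pyrazol-1-yl in place of 1H-pyrazol-1-yl. The step of a number 0.40 log units higher from compound 1 to compound 2 (beyond the scatter) concerns only where the pyrazole sits, so it bears less on this change. For the measured compounds named here, no cyclopropyl compound has been measured, so neither step sizes the change directly. The expected result is a slight fall, with no shift beyond the scatter: an estimated a number 0.10 log units lower from compound 3 to compound 4 (within the scatter). For compound 4 the estimate is 2.4, with an expected range of 2 to 2.8.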

Compound 4, distribution coefficient: 2.9
The estimate for compound 4 lay 0.50 log units below the measured number, outside the stated range (above it).
By their numbers in this assay, from the lowest: compound 1; then compound 2; then compound 3; then compound 4.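

On the aromatic carbon para to a chloro group, this assay gives a higher number with cyclopropyl than with either pyrazole, by a number 0.40 log units higher from compound 3 to compound 4 (beyond the scatter) and by a number 0.90 log units higher from compound 2 to compound 4 (beyond the scatter) in the comparison with the unsubstituted pyrazole, so the group of 3 heavy atoms outranks the one of 7. The widest gap in the series, a number 1.30 log units higher from compound 1 to compound 4 (beyond the scatter) and the only one graded large, also includes the move of the group on the ring. Nothing available explains these rises.

Still open, as far as these compounds go, is whether a cyclobutyl ring, a longer alkyl chain or an amine on this carbon would extend the rise or reverse it.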